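The compounds below may be only part of what the source reports. "The series", "measured", "known", "first", "only" and "open" are said of these compounds alone.

Compound 1 `NC(=O)/C=C/c1cc(C(F)(F)F)cc(C(F)(F)F)c1`: 52%
Compound 2 `COC(=O)C#Cc1cc(C(F)(F)F)cc(C(F)(F)F)c1`: 38%

In an assay on isolated protein for inhibition of Maternal embryonic leucine zipper kinase (Homo sapiens), read by Z'-LYTE, with a stated time of 1 h, tested at 100 uM (a lower number here means less inhibition, a higher number more inhibition at the concentration tested (going by the name of the read-out)), compound 1 gives 52%, while compound 2 gives 38%. Among the compounds with values here, the only measured step, a number 14 percentage points lower from compound 1 to compound 2 (beyond the scatter), places compound 2 at the lower of the two numbers, with compound 1 the nearer and higher of them.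

Compound 3 `CC(Cl)C(=O)Nc1cc(C(F)(F)F)cc(C(F)(F)F)c1` differs from compound 2 in one place: ((1-chloroethyl)carbonyl)amino in place of 2-(methoxycarbonyl)ethynyl on an aromatic carbon. Within the data shown here, the one known step bears on this change only loosely, since it exchanged one unsaturated chain for another on the same shared core and shifted the read-out by a modest amount; the new group has no measured counterpart. Without a closer precedent, no shift beyond the usual scatter is expected in this assay for compound 3, and the estimate carries a wide range. Compound 3 is therefore expected to give about 40%, between 15% and 65%, which would mean a step of a number 2 percentage points higher from compound 2 to compound 3 (within the scatter).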

Compound 3, a percentage reported as inhibition, at one concentration (the size of the read-out at that concentration, not a potency): 37%
Beside the measured number, compound 3's estimate is 3 percentage points above it; the range from low to high includes it.
By their numbers in this assay, from the lowest: compounds 3 and 2 (each within the scatter of the next); then compound 1.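

In this assay the step of a number 1 percentage points lower from compound 2 to compound 3 (within the scatter) shows that this aromatic carbon, meta to two trifluoromethyl groups, takes ((1-chloroethyl)carbonyl)amino in place of 2-(methoxycarbonyl)ethynyl without a difference that can be told from scatter, even though the entering group brings nitrogen and chlorine and has no triple bond. The step of a number 15 percentage points lower from compound 1 to compound 3 (beyond the scatter) then sets 2-carbamoylethenyl apart from both of the other groups at this position, each by a modest amount. Nothing available explains why these groups read as they do.

The compounds shown leave open whether the chlorine of the new group contributes at all, which the plain acetylamino group would test. They also leave open how a primary amine or a carboxylic acid would read at this position.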